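Extending the Azetidine Amide on an Inactive Series

The compounds below may be only part of what the source reports. "The series", "measured", "known", "first", "only" and "open" are said of these compounds alone.

Compound 2 `C=CC(=O)N1CC(Oc2ccc(Oc3c(-c4ccc(F)cc4)sc4cc(O)ccc34)cc2)C1` stands in a functional assay on MDA-MB-231 cells (Homo sapiens) for antiproliferative activity, read by CCK-8 assay, with a stated time of 48 h (on this read-out lower numbers stand for stronger inhibition and higher numbers for weaker inhibition), only at a limit of the assay, > 50000 nM. The two compounds measured beside it sit at the same place. Compound 1 `C=C(C)C(=O)NCCOc1ccc(Oc2c(-c3ccc(F)cc3)sc3cc(O)ccc23)cc1` gives in this assay the limit > 50000 nM. Compound 3 `CN(C)C(=O)/C=C/CNCCOc1ccc(Oc2c(-c3ccc(F)cc3)sc3cc(O)ccc23)cc1` likewise gives the limit > 50000 nM. The steps among these three, a step that the two limits leave unreadable from compound 1 to compound 2, a step that the two limits leave unreadable from compound 1 to compound 3 and a step that the two limits leave unreadable from compound 2 to compound 3, cannot be read because of the limit of > 50000 nM in this assay, at which 3 of the 3 values shown sit.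

The unmeasured compound 4 `O=C(/C=C/CN1CC(Oc2ccc(Oc3c(-c4ccc(F)cc4)sc4cc(O)ccc34)cc2)C1)N1CCC1` arises from compound 2 by a single change: 3-((azetidin-1-yl)carbonyl)prop-2-en-1-yl in place of vinylcarbonyl on an amine nitrogen in a ring. Within the data shown here, none of the measured steps bears readably on this change; the three measured pairs show only that varying the group on the oxygen on an aromatic ring or on the amine nitrogen left every compound at the limit. On that basis compound 4 is expected to give about 60000 nM, within a range from 20000 nM to 200000 nM. The step this estimate means, a step that the limit leaves unreadable from compound 2 to compound 4, is expected to be none beyond the scatter, and the most likely outcome is that this assay again reports only a limit.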

Compound 4, half-maximal inhibitory concentration: > 50000 nM
Compound 4 was reported as a limit; the forecaster's own chance of this, stated with the estimate: 85%; the middle value lies beyond the limit too.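

Compound 4, like compound 2, stands only at a limit in this assay, and the step between them cannot be read: the limit of > 50000 nM in this assay, at which 4 of the 4 values shown sit.

The compounds shown leave open how these compounds rank against one another and which change to the shared core, if any, would give a measurable value.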